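This account rests on a few compounds, and the source may have more. Where it says the series, first, only, none or still open, it means among the compounds named here.

Measured compounds:
compound 1 `Cc1ccccc1C(=O)Nc1ccc(S(=O)(=O)NC2CCN(C(=O)CCCCN)CC2)c2ccccc12`, in an assay on L1.2 cells for binding affinity to C-C chemokine receptor type 8 (Homo sapiens) (a lower number here means a stronger inhibitor, a higher number a weaker inhibitor), compound 1 gives 199 nM;
compound 2 `Cc1ccccc1C(=O)Nc1ccc(S(=O)(=O)NC2CCN(C(=O)N(C)C)CC2)c2ccccc12`, in this assay compound 2 gives 1.6 nM.

Compound 2 stands lowest of the two numbers; the gap between them is a 120-fold lower number from compound 1 to compound 2 (2.09 log units; beyond the scatter).

Compound 3 `Cc1ccccc1C(=O)Nc1ccc(S(=O)(=O)NC2CCN(C(=O)N3CCOCC3)CC2)c2ccccc12` is not yet measured. The change is morpholin-4-yl in place of dimethylamino on a carbonyl carbon. For the measured compounds named here, the only measured step at the same place is a 120-fold lower number from compound 1 to compound 2 (2.09 log units; beyond the scatter), a large one; the new change exchanges one uncharged amine for another, so a small step, if any beyond the scatter, is expected: a 1.9-fold higher number from compound 2 to compound 3 (0.27 log units; within the scatter). Compound 3 is estimated at 3 nM, range 1 nM to 10 nM.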

Compound 3, inhibition constant: 6.3 nM
Compound 3: middle estimate off by 2.1-fold (0.32 log units), on the low side; low and high end bracket the measured number.
By their numbers in this assay, from the lowest: compound 2; then compound 3; then compound 1.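

At this carbonyl carbon the assay separates two groups with no net charge: morpholin-4-yl, with its six-membered ring and one hydrogen-bond acceptor, gives a modest loss against dimethylamino (a 3.9-fold higher number from compound 2 to compound 3 (0.60 log units; beyond the scatter)). The step from the 4-aminobutyl compound remains large (a 32-fold lower number from compound 1 to compound 3 (1.50 log units; beyond the scatter)), so this ring stays on the strong side of the series. Nothing available explains the gap between the two groups.

Open, on these data alone, is whether piperidin-1-yl, with a ring carbon in place of the morpholine oxygen, would fall with compound 3. Also open, as far as these compounds go, is how diethylamino, with longer chains, would compare with compound 2.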